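A few compounds are considered here, and "the series" means these few. Any claim that something is new, unique, unknown or untested is made for them only; others in the source may bear on it.

The measured compounds and their values:

Compound 1 `O=C1O[C@@H](CN2CCC(O)CC2)CN1c1ccc(-n2cc(-c3ccccn3)cn2)c(F)c1` gives 1.63 in a physicochemical assay for lipophilicity, read by HPLC, measured as octanol-water partition; on this read-out higher numbers stand for higher lipophilicity and lower numbers for lower lipophilicity.
Compound 2 `CS(=O)(=O)NC[C@H]1CN(c2ccc(-n3cc(-c4ccccn4)cn3)c(F)c2)C(=O)O1` gives 1.38 in this assay.
Compound 3 `COC(=O)NC[C@H]1CN(c2ccc(-n3cc(-c4ccccn4)cn3)c(F)c2)C(=O)O1` gives 2.03 in this assay.

Among these three, compound 1 stands second highest; compound 2 is its nearest neighbour and lies within the scatter of it, while compound 3 sits beyond the scatter above it.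

The next compound, compound 4 `O=C(NC[C@H]1CN(c2ccc(-n3cc(-c4ccccn4)cn3)c(F)c2)C(=O)O1)C(F)F`, has not yet been measured in this assay. It differs from compound 1 in one place: ((difluoromethyl)carbonyl)amino in place of 4-hydroxypiperidin-1-yl on a saturated chain carbon bound to a saturated ring carbon.

Two measured steps start from the same group at the same place: a number 0.25 log units lower from compound 1 to compound 2 (within the scatter) and a number 0.40 log units higher from compound 1 to compound 3 (beyond the scatter). The gap between those two end points is itself a measured step, a number 0.65 log units higher from compound 2 to compound 3 (beyond the scatter). The group entering in compound 4 resembles the carbamate of compound 3 more than the sulfonamide of compound 2, so a modest upward step is expected, a number 0.27 log units higher from compound 1 to compound 4 (within the scatter). For compound 4 the estimated value in this assay is 1.9, expected to fall between 1.5 and 2.3.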

Compound 4, partition coefficient: 1.9
Estimate against measurement, compound 4: no gap at the digits printed; low and high end bracket the measured number.
By their numbers in this assay, from the lowest: compounds 2, 1, 4 and 3 (each within the scatter of the next, the first and the last beyond it).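

At this place, on a saturated chain carbon bound to a saturated ring carbon, in this assay ((difluoromethyl)carbonyl)amino can stand in for 4-hydroxypiperidin-1-yl without a change that clears the scatter (a number 0.27 log units higher from compound 1 to compound 4 (within the scatter)). Difluoromethyl in place of methoxy on the carbonyl carbon also stays inside the scatter (a number 0.13 log units lower from compound 3 to compound 4 (within the scatter)), whereas (difluoromethyl)carbonyl in place of methylsulfonyl on the amine nitrogen goes beyond it (a number 0.52 log units higher from compound 2 to compound 4 (beyond the scatter)). The gap from methylsulfonyl therefore now appears with two different carbonyl groups, in compound 3 and compound 4, rather than with one.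

Nothing available explains these steps. Still open, from the compounds shown here alone, is whether a plain acetyl group on that nitrogen, or a free amine at this place, would sit with compound 4 or with compound 2.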